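The source may report more compounds than this note shows. Statements on the series, on what has been measured and on what is new or still open speak of the compounds shown alone.

Measured compounds in a functional assay on HL-60 cells (Homo sapiens) for cytotoxicity, read by MTT assay, with a stated time of 48 h; on this read-out higher numbers stand for weaker inhibition and lower numbers for stronger inhibition:
compound 1 `O=C(O)CN1C(=O)/C(=C/c2nc3ccccc3n2Cc2ccc(F)cc2)SC1=S` gives 1420 nM
compound 2 `O=C(O)CN1C(=O)/C(=C/c2nc3ccccc3n2Cc2ccc(Cl)cc2)SC1=S` gives 2650 nM
compound 3 `Cc1ccc(Cn2c(/C=C3\SC(=S)N(CC(=O)O)C3=O)nc3cc(Cl)ccc32)cc1` gives 2720 nM

Compound 2 and compound 1 differ by fluoro in place of chloro on an aromatic carbon, and the step is a 1.9-fold lower number from compound 2 to compound 1 (0.27 log units; within the scatter). Compound 3 carries a different core; the difference between the two cores is not broken down here, and the values of compound 3 and compound 2 lie within the scatter of each other.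

Compound 4 `Cc1ccc(Cn2c(/C=C3\SC(=S)N(CC(=O)O)C3=O)nc3cc(F)ccc32)cc1` is not yet measured. It differs from compound 3 by fluoro in place of chloro on an aromatic carbon. This is the same kind of change as that from compound 2 to compound 1, but the place differs: in compound 3 it sits on a ring that is part of a fused system, meta and para to a fused ring, whereas in compound 2 it sits para to a large group.

For this assay, a step like a 1.5-fold lower number from compound 3 to compound 4 (0.18 log units; within the scatter) is expected, resting on the earlier step of a 1.9-fold lower number from compound 2 to compound 1 (0.27 log units; within the scatter), which stayed within the scatter. Compound 4 is estimated at 1800 nM.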

Compound 4, half-maximal inhibitory concentration: 1170 nM
For compound 4 the middle estimate is 1.5-fold (0.19 log units) above the measured one; low and high end bracket the measured number.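

In this assay fluoro in place of chloro on an aromatic carbon gives a 2.3-fold lower number from compound 3 to compound 4 (0.37 log units; beyond the scatter) on the core of compound 3, in the same direction as on the core of compound 1. Two pairs set no rule for other cores, the earlier step on its own stays within the scatter, the change sits at different places in the two pairs, and core and place are not separated. The change carries across these two cores without a difference in the size of the step: the same change on two cores in this assay, a 1.9-fold lower number (0.27 log units; within the scatter) from compound 2 to compound 1 and a 2.3-fold lower number (0.37 log units; beyond the scatter) from compound 3 to compound 4, 1.2-fold (0.10 log units) apart, within the scatter of two such steps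

The compounds shown leave open how a bromo or a methoxy group would compare at these places. They also leave open whether the step holds when the carboxylic acid gives way to an amide.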